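A Ring Swap Repeated on a Second Core

This account rests on a few compounds, and the source may have more. Where it says the series, first, only, none or still open, it means among the compounds named here.

Compound 1 `Cc1c(OCCCCOc2cccc(F)c2F)ccc(C(=O)CC(C)C)c1O` is characterised in a functional assay for binding affinity to metabotropic glutamate receptor 2 (Homo sapiens), read by GTPgammaS binding (on this read-out higher numbers stand for an effect only at larger amounts of compound and lower numbers for an effect already at smaller amounts), where compound 1 gives 384 nM. Compound 2 `Cc1c(OCCCCOc2cccnc2)ccc(C(=O)CC(C)C)c1O` differs from it by pyridin-3-yl in place of 2,3-difluorophenyl on an oxygen on a saturated carbon, and in this assay compound 2 gives 1720 nM; this single change produced a 4.5-fold higher number from compound 1 to compound 2 (0.65 log units; beyond the scatter). Compound 3 `CC(C)CC(=O)c1ccc(OCCCCOc2cccc(F)c2F)c(Br)c1O` carries a second core, differing from compound 1 by bromo in place of methyl on an aromatic carbon. In this assay compound 3 gives 558 nM, and the step is a 1.5-fold higher number from compound 1 to compound 3 (0.16 log units; within the scatter), so the two cores cannot be told apart on this read-out.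

Compound 4 `CC(C)CC(=O)c1ccc(OCCCCOc2cccnc2)c(Br)c1O` has not yet been measured. For the measured compounds named here, it differs from compound 3 by pyridin-3-yl in place of 2,3-difluorophenyl on an oxygen on a saturated carbon, which is the same change as the one from compound 1 to compound 2, made at a place described in the same words. Because the earlier step was a 4.5-fold higher number from compound 1 to compound 2 (0.65 log units; beyond the scatter), a step of about the same size is expected here, a 4.5-fold higher number from compound 3 to compound 4 (0.65 log units; beyond the scatter). Since compound 3 starts from 558 nM, the estimate for compound 4 in this assay is 2500 nM, with a likely range from 1000 nM to 6000 nM.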

Compound 4, half-maximal effective concentration: 575 nM
Beside the measured number, compound 4's estimate is 4.3-fold (0.64 log units) above it; measured number outside the range, below it.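

In this assay, the swap from 2,3-difluorophenyl to pyridin-3-yl does not carry over from the core of compound 1 to the core of compound 3, where the result is a 1.0-fold higher number from compound 3 to compound 4 (0.01 log units; within the scatter), and the two steps clearly disagree: the same change on two cores in this assay, a 4.5-fold higher number (0.65 log units; beyond the scatter) from compound 1 to compound 2 and a 1.0-fold higher number (0.01 log units; within the scatter) from compound 3 to compound 4, 4.3-fold (0.64 log units) apart, beyond the scatter of two such steps. The same four compounds can be read along the other edge, where bromo in place of methyl gives a 3.0-fold lower number from compound 2 to compound 4 (0.48 log units; beyond the scatter), yet this exchange made no readable difference with the 2,3-difluorophenyl group in place: the same change on two cores in this assay, a 1.5-fold higher number (0.16 log units; within the scatter) from compound 1 to compound 3 and a 3.0-fold lower number (0.48 log units; beyond the scatter) from compound 2 to compound 4, 4.3-fold (0.64 log units) apart, beyond the scatter of two such steps. So in these four compounds the size of each step depends on what is present at the other place, but this does not show why, and one such set of four gives no general rule for the series.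

On these data alone, it remains open whether a ring such as pyridin-4-yl or plain phenyl would behave like pyridin-3-yl on both cores. As far as these compounds go, it is equally open whether chloro in place of bromo would give the same pattern as bromo does.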